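A few compounds are considered here, and "the series" means these few. Any claim that something is new, unique, unknown or untested is made for them only; others in the source may bear on it.

Measured compounds in an assay on isolated protein for inhibition of DNA topoisomerase 1 (Homo sapiens), with a stated time of 30 min, tested at 100 uM; on this read-out lower numbers stand for less inhibition and higher numbers for more inhibition at the one concentration tested (going by the name of the read-out):
compound 1 `Cc1ccsc1-c1cc(-c2ccoc2)cc(-c2ccco2)n1`: 5.4%
compound 2 `Cc1ccsc1-c1cc(-c2ccoc2)cc(-c2ccc(Cl)cc2)n1`: 85.9%
compound 3 `Clc1ccc(-c2cc(-c3ccoc3)cc(-c3ccco3)n2)s1`: 9.6%

Compound 1 stands lowest of the three numbers in this assay; compound 3 sits closest to it, and compound 2 furthest away. Compound 4 `Cc1ccsc1-c1cc(-c2ccc(Cl)o2)cc(-c2ccco2)n1` has not yet been measured. It differs from compound 1 in one place: 5-chlorofuran-2-yl in place of furan-3-yl on an aromatic carbon.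

Two measured steps from compound 1 bear on this. The step of a number 80.5 percentage points higher from compound 1 to compound 2 (beyond the scatter) put a 4-chlorophenyl group where a furan-2-yl group had been, and the number rose a great deal. The step of a number 4.2 percentage points higher from compound 1 to compound 3 (within the scatter) put a 5-chlorothiophen-2-yl group where a 3-methylthiophen-2-yl group had been, and the number stayed within the scatter. Going by the values given here, neither step touches the ring carbon opposite the ring nitrogen, where the change in compound 4 takes place, so there is no direct precedent. One step that brings in a chlorine gave a large rise; the other gave none beyond the scatter. On balance a moderate rise in this assay is expected for compound 4, with a wide range, which is the estimated step of a number 14.6 percentage points higher from compound 1 to compound 4 (beyond the scatter). Compound 4 is therefore expected to give 20%, between 3% and 55%.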

Compound 4, a percentage reported as inhibition, at one concentration (the size of the read-out at that concentration, not a potency): 7.8%
Compound 4: the middle estimate sits 12.2 percentage points above what was measured, within the range that was stated.
By their numbers in this assay, from the lowest: compounds 1, 4 and 3 (each within the scatter of the next); then compound 2.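

In this assay, going by these compounds alone, the swap of furan-3-yl for 5-chlorofuran-2-yl opposite the ring nitrogen gives the first reading at this position, a number 2.4 percentage points higher from compound 1 to compound 4 (within the scatter), so this change leaves the number about where it stood. A chlorine-bearing group on the core is therefore not enough on its own to raise the number: compound 4 joins compound 3, whose step also lies within the scatter, while compound 2 goes against this with a number 80.5 percentage points higher from compound 1 to compound 2 (beyond the scatter), a change made in a different place. Nothing among the data shown accounts for this difference between the steps.

The step to compound 4 changes the point of attachment of the furan and adds the chlorine together, so the compounds shown cannot separate the two, and they also leave open whether this position can respond at all in this assay. A quite different group opposite the ring nitrogen, such as an amine or a carboxylic acid, or the 4-chlorophenyl group of compound 2 placed there, might answer that, and the present compounds give no indication of the outcome.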